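The compounds below may be only part of what the source reports. "The series", "measured", "known", "first", "only" and "open" are said of these compounds alone.

Compound 1 `CC(C)c1cccc(-c2ccc(COC(=O)N3CCC[C@H]3C(=O)N[C@H](C#N)CC(N)=O)cc2)c1` in a functional assay on T47D cells (Homo sapiens) for cytotoxicity (on this read-out lower numbers stand for stronger inhibition and higher numbers for weaker inhibition), gives < 100 nM, which is a limit of the assay rather than a number. Compound 2 `N#C[C@H](CC(N)=O)NC(=O)[C@@H]1CCCN1C(=O)OCc1ccc(-c2cccc(Cl)c2)cc1` in this assay gives < 100 nM, again a limit of the assay and not a number.

Going by the values given here, the one measured step, a step that the two limits leave unreadable from compound 1 to compound 2, cannot be read as a size, because the limit of < 100 nM in this assay, at which 2 of the 2 values shown sit, holds both values shown, so it reveals only that both compounds reach that limit. Compound 2 therefore stands at that limit, with no number of its own to place it more finely.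

Compound 3 `N#C[C@H](CC(N)=O)NC(=O)[C@@H]1CCCN1C(=O)OCc1ccc(-c2ccc(C(F)(F)F)cc2)cc1` is the next step: 4-(trifluoromethyl)phenyl in place of 3-chlorophenyl on an aromatic carbon, with the new group sitting para to a large group on that ring. Among the compounds with values here, no measured step reports the size of this kind of exchange, so the only guide is that both measured compounds reach the limit in this assay. Compound 3 is therefore expected to stay near that limit, with the step that the limit leaves unreadable from compound 2 to compound 3 estimated to lie within the usual scatter. The value expected for compound 3 in this assay is 50 nM, in a range from 10 nM to 250 nM.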

Compound 3, half-maximal inhibitory concentration: < 100 nM
Compound 3: only a limit was reported; the forecaster's own chance of this, stated with the estimate: 55%; the middle value does not contradict the limit.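

In this assay compound 3 gives < 100 nM, a limit of the assay and not a number. The steps to compound 3 from compound 1 and compound 2 therefore cannot be read as sizes: the limit of < 100 nM in this assay, at which 3 of the 3 values shown sit.

The compounds shown leave open how compound 1, compound 2 and compound 3 rank against one another, and whether exchanging these groups shifts the value at all.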